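Spiro pyrrolidinone phenazine series: aryl swap on the triazole

The source may report more compounds than this note shows. Statements on the series, on what has been measured and on what is new or still open speak of the compounds shown alone.

Compound 1 `Cc1ccc(Cl)cc1-n1nncc1CN1C(=O)C2(C(C#N)=C(N)Oc3c2c2nc4ccccc4nc2c2ccccc32)c2ccccc21` carries a 5-chloro-2-methylphenyl on the triazole nitrogen. In a functional assay on A549 cells (Homo sapiens) for antiproliferative activity, read by MTT assay, with a stated time of 48 h (on this read-out higher numbers stand for weaker inhibition and lower numbers for stronger inhibition), compound 1 gives only a limit, > 50000 nM. Compound 2 `N#CC1=C(N)Oc2c(c3nc4ccccc4nc3c3ccccc23)C12C(=O)N(Cc1cnnn1-c1ccc(F)c(Cl)c1)c1ccccc12` differs by 3-chloro-4-fluorophenyl in place of 5-chloro-2-methylphenyl on an aromatic nitrogen. In this assay compound 2 likewise gives only a limit, > 50000 nM. The step that the two limits leave unreadable from compound 1 to compound 2 cannot be read, due to the limit of > 50000 nM in this assay, at which 3 of the 3 values shown sit. Compound 3 `Cc1ccc(Cl)cc1-n1nncc1CN1C(=O)C2(C(C#N)=C(N)Oc3c(N)cc4nc5ccccc5nc4c32)c2ccccc21` bears an amino group on the core; how its core differs from that of compound 1 is not broken down here. In this assay compound 3 gives only a limit, > 50000 nM. Compound 4 `N#CC1=C(N)Oc2c(N)cc3nc4ccccc4nc3c2C12C(=O)N(Cc1cnnn1-c1ccc(F)c(Cl)c1)c1ccccc12` differs from compound 3 by the same change, (3-chloro-4-fluorophenyl in place of 5-chloro-2-methylphenyl on an aromatic nitrogen). Since that change left no readable step from compound 1 to compound 2, compound 4 is expected to give 50000 nM, within 20000 nM to 100000 nM. This estimate means an expected step of a number no higher from compound 3 to compound 4 (the limit leaves the size open).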

Compound 4, half-maximal inhibitory concentration: 43400 nM
The estimate for compound 4 lay 1.2-fold (0.06 log units) above the measured number, within the range that was stated.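

In this assay, the aryl swap on the amino-bearing core gives an at least 1.1-fold lower number from compound 3 to compound 4 (0.06 log units; that floor lies within the scatter). Compound 3 gives only a limit, > 50000 nM. The swap therefore ends in a measured number for compound 4, but the size of the step stays open, and this floor does not show that the change carries the same way between cores, since the step on the core of compound 1 cannot be read, due to the limit: the limit of > 50000 nM in this assay, at which 3 of the 4 values shown sit.

The compounds shown leave open how the amino group on the core would compare with a hydroxyl group or a carboxylic acid there. They also leave open how a longer alkyl chain on the triazole nitrogen, in place of the aryl ring, would read.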